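This account rests on a few compounds, and the source may have more. Where it says the series, first, only, none or still open, it means among the compounds named here.

Measured so far:
compound 1, `CCCC(C)C(=O)NCC(C)(C)CC1=C(O)C(=O)c2ccccc2C1=O`, 48100 nM
compound 2, `CCCCCC(=O)OCC(C)(C)CC1=C(O)C(=O)c2ccccc2C1=O`, 169000 nM

In an ADME assay on Vero cells (Chlorocebus sabaeus) for cytotoxicity, read by reporter gene assay, with a stated time of 4 days (a lower number here means a stronger inhibitor, a higher number a weaker inhibitor), compound 2 gives the highest of the two numbers. Within the data shown here, its nearest neighbour is compound 1; the one measured step runs a 3.5-fold higher number from compound 1 to compound 2 (0.55 log units; beyond the scatter), and it changes the group on the side chain rather than the chain length.

Compound 3 is `CCCCCCCCCCCCCC(=O)OCC(C)(C)CC1=C(O)C(=O)c2ccccc2C1=O`. Against compound 2 the difference is octyl in place of hydrogen on a saturated chain carbon, five bonds along the chain from a carbonyl carbon. Among the measured compounds shown here, no measured step changes the length of the chain on the ester, so nothing among the measured compounds bears directly on this change; the step from compound 1 to compound 2 concerns a different part of the molecule and gives no guide to the direction here. The expectation for compound 3 in this assay is therefore a step of no clear direction, likely within the scatter, a 1.2-fold lower number from compound 2 to compound 3 (0.08 log units; within the scatter). Compound 3 is estimated at 140000 nM, within a range from 40000 nM to 400000 nM.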

Compound 3, half-maximal inhibitory concentration: 58400 nM
For compound 3 the middle estimate is 2.4-fold (0.38 log units) above the measured one, within the range that was stated.
By their numbers in this assay, from the lowest: compounds 1 and 3 (each within the scatter of the next); then compound 2.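

In this assay, the length of the ester chain proves to matter as well: octyl in place of hydrogen on a saturated chain carbon, five bonds along the chain from a carbonyl carbon, gives a 2.9-fold lower number from compound 2 to compound 3 (0.46 log units; beyond the scatter) and is a modest step beyond the scatter. The earlier step, a 3.5-fold higher number from compound 1 to compound 2 (0.55 log units; beyond the scatter), changed the group on the side chain and ran the other way, so the series now holds two changes that move the number in opposite directions. No measurement available here accounts for the direction or size of the step on the ester chain.

On these data alone, with only these two ester chains, it remains open whether the number falls steadily with chain length or changes only at some particular length. A longer chain, or an amine or a carboxylic acid on the ester chain, would test how general the step is.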